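Dropping a Methoxy Group: What to Expect for Compound 4

The source may hold more compounds than are shown below. What is called first, only, known or untested is meant among the compounds shown, and "the series" means these compounds.

Measured in a functional assay on RPMI-8226 cells (Homo sapiens) for inhibition, read by sulforhodamine B assay, with a stated time of 48 h; on this read-out higher numbers stand for weaker inhibition of growth and lower numbers for stronger inhibition of growth:
- compound 1 `N=C(N)c1ccc(-c2ccc(-c3cc(Cl)cc(Cl)c3)s2)s1`: 2330 nM
- compound 2 `COc1ccc(-c2ccc(-c3ccc(C(=N)N)o3)o2)cc1`: 2680 nM
- compound 3 `N=C(N)c1ccc(-c2ccc(-c3cncc4ccccc34)s2)s1`: 1780 nM

Compound 2 has the highest of the three numbers, yet compound 1 and compound 3 both sit within the usual scatter of it, so the three cannot be told apart with confidence. Compound 4 `N=C(N)c1ccc(-c2ccc(-c3ccccc3)o2)o1` differs from compound 2 in a single place: hydrogen in place of methoxy on an aromatic carbon. Among the compounds with values here, no pair of measured compounds shows this exact change, so there is no measured step to lean on. Such a small change, with no ring or charge involved, is expected to move the number little, in no clear direction, and not beyond the scatter; the expected step is a 1.1-fold higher number from compound 2 to compound 4 (0.03 log units; within the scatter). Compound 4 is therefore estimated at 2900 nM, with a range from 1200 nM to 7500 nM.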

Compound 4, concentration for 50% growth inhibition: 2890 nM
Compound 4: middle estimate off by 1.0-fold (0.00 log units), on the high side, and the stated range covers the measured number.
By their numbers in this assay, from the lowest: compounds 3, 1, 2 and 4 (each within the scatter of the next).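

In this assay, within the data shown here, hydrogen in place of methoxy on this aromatic carbon gives a 1.1-fold higher number from compound 2 to compound 4 (0.03 log units; within the scatter) and so provides the first measured step at this position. On this one pair, the methoxy group and hydrogen cannot be told apart here, so the methoxy group is not needed to keep the read-out at this level. No measurement shown explains why the two compounds read alike.

On these data alone, whether an amine or a carboxylic acid at this position would move the number beyond the scatter remains open. As far as these compounds go, whether the same change behaves alike on the core of compound 1 also remains open.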